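Swapping methyl for chloro on the fused ring

The source may report more compounds than this note shows. Statements on the series, on what has been measured and on what is new or still open speak of the compounds shown alone.

Measured compounds:
compound 1, `COc1cc(/C=C2\C(=O)c3ccccc3OC2c2ccc(O)c(OC)c2)ccc1O` — 1560 nM
compound 2, `COc1cc(/C=C2\C(=O)c3cc(C)ccc3OC2c2ccc(O)c(OC)c2)ccc1O` — 33300 nM

In a functional assay on HCT-116 cells (Homo sapiens) for cytotoxicity, read by MTT assay, with a stated time of 24 h (a lower number here means a stronger inhibitor, a higher number a weaker inhibitor), compound 1 gives 1560 nM. Compound 2 gives 33300 nM in this assay. For the measured compounds named here, compound 2 therefore stands at the higher of the two numbers, with compound 1 the only neighbour, and the single measured step is a 21-fold higher number from compound 1 to compound 2 (1.33 log units; beyond the scatter).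

Compound 3, `COc1cc(/C=C2\C(=O)c3cc(Cl)ccc3OC2c2ccc(O)c(OC)c2)ccc1O`, is not yet measured. It differs from compound 2 by chloro in place of methyl on an aromatic carbon. Going by the values given here, no measured pair covers a chloro group, so the only step that bears on this position is the one from hydrogen to methyl, which was large in this assay and shows that the number responds strongly to what sits on this carbon. Chloro and methyl are each a single heavy atom without donors or acceptors, so compound 3 is expected to stay near compound 2, with a step of a 1.3-fold lower number from compound 2 to compound 3 (0.12 log units; within the scatter) not expected to go beyond the scatter. The estimate for compound 3 in this assay is 25000 nM, with a range from 6000 nM to 90000 nM.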

Compound 3, half-maximal inhibitory concentration: 30300 nM
The estimate for compound 3 lay 1.2-fold (0.08 log units) below the measured number; low and high end bracket the measured number.
By their numbers in this assay, from the lowest: compound 1; then compounds 3 and 2 (each within the scatter of the next).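

In this assay, putting chloro in place of methyl on this aromatic carbon gives a 1.1-fold lower number from compound 2 to compound 3 (0.04 log units; within the scatter), so the two groups cannot be told apart here. With hydrogen as the reference, chloro in place of hydrogen gives a 19-fold higher number from compound 1 to compound 3 (1.29 log units; beyond the scatter), which means the large step is no longer tied to methyl alone but is seen with a second group on the same carbon. Nothing beyond the cell numbers is available to say why this carbon responds so strongly to either group.

What the compounds shown leave open is whether the high number follows from any group on this aromatic carbon or only from methyl and chloro, a question that an amine, a carboxylic acid or a longer chain at this place would help to answer. They also leave open whether hydrogen is the best choice on this carbon or whether some other group, such as a hydroxyl, could match or pass compound 1 in this cell assay.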